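Growing the para group from ethyl to tert-butyl

The compounds below may be only part of what the source reports. "The series", "measured", "known", "first", "only" and "open" are said of these compounds alone.

Measured so far:
- compound 1, `Cc1ccc(NS(=O)(=O)c2cccc(CCCCCCNC(=O)/C=C/c3cccnc3)c2)cc1`: 9.78 nM
- compound 2, `CCc1ccc(NS(=O)(=O)c2cccc(CCCCCCNC(=O)/C=C/c3cccnc3)c2)cc1`: 31.5 nM

Both compounds share one core and differ only in the small group on the outer aromatic ring. In an assay on isolated protein for inhibition of Nicotinamide phosphoribosyltransferase (Homo sapiens), read by WST assay, with stated times of 60 min, 5 min and 30 min, in the presence of a further agent that is not named here (on this read-out lower numbers stand for stronger inhibition and higher numbers for weaker inhibition), compound 1 gives 9.78 nM, and compound 2 gives 31.5 nM. For the measured compounds named here, the single measured step is a 3.2-fold higher number from compound 1 to compound 2 (0.51 log units; beyond the scatter), so compound 2 stands at the higher of the two numbers, with compound 1 as its only neighbour.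

Compound 3, `CC(C)(C)c1ccc(NS(=O)(=O)c2cccc(CCCCCCNC(=O)/C=C/c3cccnc3)c2)cc1`, has not been measured. It differs from compound 2 by tert-butyl in place of ethyl on an aromatic carbon, that is, the same position is changed once more, now to a larger branched group.

Going by the values given here, the one step that bears on this is the move from methyl to ethyl, which weakened inhibition by a modest, clearly resolved amount. Continuing in the same direction, a further loss is expected rather than a gain, though a single step is a thin basis and the size is uncertain. The expected step is a 2.5-fold higher number from compound 2 to compound 3 (0.40 log units; beyond the scatter). Compound 3 is therefore estimated at 80 nM, with a plausible range from 25 nM to 300 nM.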

Compound 3, half-maximal inhibitory concentration: 9.47 nM
Beside the measured number, compound 3's estimate is 8.4-fold (0.93 log units) above it; measured number outside the range, below it.
By their numbers in this assay, from the lowest: compounds 3 and 1 (each within the scatter of the next); then compound 2.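

In this assay the larger tert-butyl group undoes the earlier loss, with a 3.3-fold lower number from compound 2 to compound 3 (0.52 log units; beyond the scatter) showing that a bigger group at this position need not give a higher number. The step of a 1.0-fold lower number from compound 1 to compound 3 (0.01 log units; within the scatter) leaves tert-butyl and methyl indistinguishable here, so among these three compounds the number does not follow group size in a straight line, and compound 2, with its ethyl group, is the one that stands apart. Nothing available explains why ethyl parts from both the smaller and the larger group.

All three groups contain only carbon and hydrogen, so the compounds shown leave open how this position responds to groups with other atoms, such as methoxy, chlorine, trifluoromethyl or an amine. They also leave open whether isopropyl, another branched group, or a longer chain such as propyl would give a number closer to that of compound 2 or closer to that of compound 3.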